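Amide Ring Variation in a Cathepsin S Nitrile Series

This account rests on a few compounds, and the source may have more. Where it says the series, first, only, none or still open, it means among the compounds named here.

Compound 1, `N#CCNC(=O)[C@@H]1C[C@@H](S(=O)(=O)c2ccccc2C(F)(F)F)C[C@H]1C(=O)N1CCOCC1`: in an assay on isolated protein for inhibition of cathepsin S (Homo sapiens), read by fluorescence, with a stated time of 20 min (on this read-out lower numbers stand for stronger inhibition and higher numbers for weaker inhibition), compound 1 gives 0.9 nM.
Compound 2, `C[C@@H]1CN(C(=O)[C@@H]2C[C@H](S(=O)(=O)c3ccccc3)C[C@H]2C(=O)NC2(C#N)CC2)C[C@H](C)O1`: in this assay compound 2 gives 0.4 nM.
Compound 3, `N#CC1(NC(=O)[C@@H]2C[C@@H](S(=O)(=O)c3ccccc3)C[C@H]2C(=O)N2CC3CCC(C2)O3)CC1`: in this assay compound 3 gives 1 nM.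

Among the compounds with values here, compound 3 stands highest of the three numbers, though compound 1 lies within the scatter of it; the only step beyond the scatter is a 2.5-fold higher number from compound 2 to compound 3 (0.40 log units; beyond the scatter), a modest one. Compound 4, `N#CC1(NC(=O)[C@@H]2C[C@@H](S(=O)(=O)c3ccccc3)C[C@H]2C(=O)N2CCCCC2)CC1`, differs from compound 3 by a group of 6 heavy atoms (5 carbon, 1 nitrogen; one six-membered non-aromatic ring with 1 hetero atom) in place of a group of 8 heavy atoms (6 carbon, 1 nitrogen, 1 oxygen; one five-membered non-aromatic ring with 1 hetero atom, one six-membered non-aromatic ring with 2 hetero atoms), on a carbonyl carbon. Within the data shown here, only that single measured step bears on this position, and it was modest; no measured pair shows piperidin-1-yl itself. The step from compound 3 to compound 4 is therefore expected to be small, a 1.2-fold higher number from compound 3 to compound 4 (0.08 log units; within the scatter), in this assay, with no firm direction. Compound 4 is estimated at 1.2 nM, within a range of 0.5 nM to 3 nM.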

Compound 4, half-maximal inhibitory concentration: 0.8 nM
Beside the measured number, compound 4's estimate is 1.5-fold (0.18 log units) above it, within the range that was stated.
By their numbers in this assay, from the lowest: compounds 2, 4, 1 and 3 (each within the scatter of the next, the first and the last beyond it).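

Piperidin-1-yl on the carbonyl carbon gives a 1.3-fold lower number from compound 3 to compound 4 (0.10 log units; within the scatter) and a 2.0-fold higher number from compound 2 to compound 4 (0.30 log units; within the scatter). The position thus accepts a group with no hydrogen-bond acceptor, and no step beyond the scatter separates compound 4 from either neighbour, so it sits within the scatter of both compounds whose step was the only one to exceed it. Nothing available explains these steps. From the compounds shown here alone, whether piperazin-1-yl or an open chain such as diethylamino on that carbonyl carbon would stay within the same range remains open.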